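Trimethoxybenzyl purine analogues: chain variation at the ring nitrogen

The compounds below may be only part of what the source reports. "The series", "measured", "known", "first", "only" and "open" are said of these compounds alone.

This account concerns two measured compounds and one not yet measured, all sharing a trimethoxybenzyl-substituted core. Compound 1 `CCCCn1c(Cc2cc(OC)c(OC)c(OC)c2)nc2c(N)nc(F)nc21` carries a butyl chain on the aromatic nitrogen and a fluorine on the core; in a functional assay on MCF7 cells (Homo sapiens) for antiproliferative activity (on this read-out higher numbers stand for weaker inhibition and lower numbers for stronger inhibition), compound 1 gives 24000 nM. Compound 2 `CC/C=C\Cn1c(Cc2cc(OC)c(OC)c(OC)c2)nc2c(N)ncnc21` carries a pent-2-en-1-yl chain and lacks the fluorine; in this assay compound 2 gives 64600 nM. Compound 2 thus stands at the higher of the two numbers, and its gap to compound 1 is beyond the usual scatter. Compound 1 and compound 2 differ in two places at once. Nothing can be said about which of the two differences carries that gap.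

Compound 3 `COc1cc(Cc2nc3c(N)ncnc3n2CCOC(C)C)cc(OC)c1OC` differs from compound 2 in one place: isopropoxymethyl in place of but-1-en-1-yl on a saturated chain carbon bound to an aromatic nitrogen. For the measured compounds named here, since no single-change step has been measured, the expectation rests on the two numbers alone. The author expects a small step from compound 2 to compound 3, a 1.4-fold lower number from compound 2 to compound 3 (0.16 log units; within the scatter), toward a lower number but not clearly beyond the scatter. The estimate for compound 3 in this assay is therefore 45000 nM, within 15000 nM to 130000 nM.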

Compound 3, half-maximal inhibitory concentration: 38900 nM
Beside the measured number, compound 3's estimate is 1.2-fold (0.06 log units) above it; measured number inside the range.
By their numbers in this assay, from the lowest: compounds 1, 3 and 2 (each within the scatter of the next, the first and the last beyond it).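

In this assay, for the compounds shown here, the first single-change step at this place, on a saturated chain carbon bound to an aromatic nitrogen, reads as a 1.7-fold lower number from compound 2 to compound 3 (0.22 log units; within the scatter) for isopropoxymethyl in place of but-1-en-1-yl. The earlier pair could not show this, since compound 1 and compound 2 differ in two places at once. Here the change is confined to the chain, where a group with one double bond and no hydrogen-bond acceptor gives way to one with no such double bond and one hydrogen-bond acceptor, and the two numbers do not separate on this read-out. Nothing shown explains why these two chains give numbers within the scatter of each other.

What the compounds shown leave open is whether a chain ending in an amine or a carboxylic acid, or a longer chain, would move the number beyond the scatter at this place. Also open is how the gap around compound 1 divides between its butyl chain and its fluorine, as no pair shown differs in only one of those two features.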